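A few compounds are considered here, and "the series" means these few. Any claim that something is new, unique, unknown or untested is made for them only; others in the source may bear on it.

In a functional assay on HepG2 cells (Homo sapiens) for cytotoxicity, read by MTT assay (on this read-out lower numbers stand for stronger inhibition and higher numbers for weaker inhibition), compound 1 (`COc1ccc(/C=C/C(=O)c2ccc(OC)c3c2OC(C)(C)C=C3)cc1OCC=C(C)C`) gives > 10000 nM as a limit of the assay, not a number. Compound 2 (`CCC(=O)Oc1cc(/C=C/C(=O)c2ccc(OC)c3c2OC(C)(C)C=C3)ccc1OC`) gives 90 nM in this series. Compound 3 (`COc1ccc(/C=C/C(=O)c2ccc(OC)c3c2OC(C)(C)C=C3)cc1OC(=O)CCl`) gives 120 nM and so stands level with compound 2, since a 1.3-fold higher number from compound 2 to compound 3 (0.12 log units; within the scatter) is within the scatter. Next is compound 4 (`COc1ccc(/C=C/C(=O)c2ccc(OC)c3c2OC(C)(C)C=C3)cc1OC(=O)C1CC1`), with cyclopropyl in place of chloromethyl on a carbonyl carbon. Two large steps, an at least 110-fold lower number from compound 1 to compound 2 (2.04 log units; beyond the scatter) and an at least 83-fold lower number from compound 1 to compound 3 (1.92 log units; beyond the scatter), exchange the 3-methylbut-2-en-1-yl group for a carbonyl-bearing one, and compound 4 keeps the carbonyl. They therefore say little about this change. The closest guide is the change on the same acyl chain, a 1.3-fold higher number from compound 2 to compound 3 (0.12 log units; within the scatter), which was small. For the measured compounds named here, no measured compound has a ring at this place, so the range is kept wide. The estimated change is a 1.2-fold higher number from compound 3 to compound 4 (0.07 log units; within the scatter) and no step beyond the scatter is expected. For compound 4 the expected value is 140 nM, with an estimated range from 50 nM to 500 nM in this assay.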

Compound 4, half-maximal inhibitory concentration: 220 nM
Beside the measured number, compound 4's estimate is 1.6-fold (0.20 log units) below it; low and high end bracket the measured number.
By their numbers in this assay, from the lowest: compounds 2, 3 and 4 (each within the scatter of the next, the first and the last beyond it). At a limit, above all of these: compound 1.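

For the compounds shown here, with the first ring at this place, the carbonyl carbon gives a graded reading in this assay: cyclopropyl in place of chloromethyl stays within the scatter, a 1.8-fold higher number from compound 3 to compound 4 (0.26 log units; within the scatter), whereas cyclopropyl in place of ethyl gives the first step beyond the scatter among the three acyl compounds, a 2.4-fold higher number from compound 2 to compound 4 (0.39 log units; beyond the scatter), a modest one. The ring therefore keeps compound 4 with the carbonyl-bearing compounds, and the large step from the 3-methylbut-2-en-1-yl group also holds for it, an at least 45-fold lower number from compound 1 to compound 4 (1.65 log units; beyond the scatter). The value of compound 1 is a limit of the assay and not a number: the limit of > 10000 nM in this assay, at which 1 of the 4 values shown sits.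

Still open, going by these compounds, is how a longer acyl chain, a cyclohexyl ring or an amine on the chain would read at this place. On these data alone, a free hydroxyl on the same oxygen, carrying no acyl group, is also open.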